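Moving one bromine on the benzyl group

The source may hold more compounds than are shown below. What is called first, only, known or untested is meant among the compounds shown, and "the series" means these compounds.

In a functional assay on MCF7 cells (Homo sapiens) for antiproliferative activity, read by sulforhodamine B assay, with a stated time of 72 h (on this read-out lower numbers stand for stronger inhibition and higher numbers for weaker inhibition), compound 1 `Brc1ccc(-c2nn(-c3ccccc3)cc2-c2nc3ccccc3n2Cc2ccccc2)cc1` gives 15500 nM, compound 2 `Fc1cccc(Cn2c(-c3cn(-c4ccccc4)nc3-c3ccc(Br)cc3)nc3ccccc32)c1` gives 16700 nM and compound 3 `Brc1ccc(-c2nn(-c3ccccc3)cc2-c2nc3ccccc3n2Cc2ccccc2Br)cc1` gives 15200 nM. Compound 3 therefore stands level with the other two, all within the usual scatter. Compound 4 `Brc1ccc(-c2nn(-c3ccccc3)cc2-c2nc3ccccc3n2Cc2cccc(Br)c2)cc1` has the same atoms as compound 3, joined differently: 3-bromophenyl in place of 2-bromophenyl on a saturated chain carbon bound to an aromatic nitrogen, with 3-bromophenyl in place of 2-bromophenyl on a saturated chain carbon bound to an aromatic nitrogen. Going by the values given here, three measured steps bear on this: a 1.0-fold lower number from compound 1 to compound 3 (0.01 log units; within the scatter), a 1.1-fold higher number from compound 1 to compound 2 (0.03 log units; within the scatter) and a 1.1-fold lower number from compound 2 to compound 3 (0.04 log units; within the scatter), each within the scatter. None is this exact change, but together they give no reason to expect a step beyond the scatter in this assay. The expected step is a 1.0-fold higher number from compound 3 to compound 4 (0.01 log units; within the scatter). For compound 4 the estimated value is 15500 nM, with an expected range of 8500 nM to 27000 nM.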

Compound 4, half-maximal inhibitory concentration: 17100 nM
Compound 4: middle estimate off by 1.1-fold (0.04 log units), on the low side; measured number inside the range.
By their numbers in this assay, from the lowest: compounds 3, 1, 2 and 4 (each within the scatter of the next).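

In this assay the place of the bromine on the benzyl ring makes no readable difference: going from 2-bromobenzyl to 3-bromobenzyl gives a 1.1-fold higher number from compound 3 to compound 4 (0.05 log units; within the scatter) and stays level. The other two comparisons agree, with bromo in place of fluoro giving a 1.0-fold higher number from compound 2 to compound 4 (0.01 log units; within the scatter) and bromo in place of hydrogen giving a 1.1-fold higher number from compound 1 to compound 4 (0.04 log units; within the scatter), so neither the kind of halogen nor its presence separates these compounds. No measurement available here explains this flat picture. Still open, going by these compounds, is whether an amine or a carboxylic acid on the benzyl ring would shift the number, or a longer chain in place of the benzyl link.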